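Trading a Methyl for Chlorine on the Triazole-Bound Phenyl

The compounds below may be only part of what the source reports. "The series", "measured", "known", "first", "only" and "open" are said of these compounds alone.

Within the data shown here, compound 2 `Cc1cccc(-n2nncc2CN2C(=O)C3(C(C#N)=C(N)Oc4c3c3nc5ccccc5nc3c3ccccc43)c3ccccc32)c1` holds the only number seen so far in a functional assay on A549 cells (Homo sapiens) for antiproliferative activity, read by MTT assay, with a stated time of 48 h (a lower number here means a stronger inhibitor, a higher number a weaker inhibitor), where compound 2 gives 39600 nM. Compound 1 `Cc1ccccc1-n1nncc1CN1C(=O)C2(C(C#N)=C(N)Oc3c2c2nc4ccccc4nc2c2ccccc32)c2ccccc21` reaches only a limit of this assay, > 50000 nM, so for it no number is known (the limit of > 50000 nM in this assay, at which 1 of the 2 values shown sits). Among the measured compounds shown here, the single measured step, an at least 1.2-fold lower number from compound 1 to compound 2 (0.10 log units; that floor lies within the scatter), involves the same position on the triazole that changes here, but its size is only a floor and lies within the scatter, so it gives no firm direction.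

Compound 3 `N#CC1=C(N)Oc2c(c3nc4ccccc4nc3c3ccccc23)C12C(=O)N(Cc1cnnn1-c1ccccc1Cl)c1ccccc12` differs from compound 2 in one place: 2-chlorophenyl in place of 3-methylphenyl on an aromatic nitrogen. For the measured compounds named here, no measured step shows what a chlorine in place of a methyl does on this phenyl, and the return to a 2-substituted phenyl is the pattern of compound 1, which reached only a limit. Compound 3 is therefore expected to sit near compound 2 or somewhat weaker, a step of a 1.2-fold higher number from compound 2 to compound 3 (0.08 log units; within the scatter), with an estimated value of 48000 nM, between 20000 nM and 110000 nM.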

Compound 3, half-maximal inhibitory concentration: 42600 nM
Estimate against measurement, compound 3: 1.1-fold (0.05 log units) above; measured number inside the range.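

In this assay, the change from 3-methylphenyl to 2-chlorophenyl on the triazole leaves no difference that can be told from scatter (a 1.1-fold higher number from compound 2 to compound 3 (0.03 log units; within the scatter)). Among these compounds, this swap alters both the group and its place on the phenyl ring, so the result shows only that this combined change does not separate the two compounds. With the 2-substituted phenyl kept, chloro in place of methyl gives a step that is only a floor and also lies within the scatter (an at least 1.1-fold lower number from compound 1 to compound 3 (0.06 log units; that floor lies within the scatter)), and compound 1 remains a limit of the assay, not a number: the limit of > 50000 nM in this assay, at which 1 of the 3 values shown sits.

The effects of the group and its place remain unseparated, as 3-chlorophenyl and 2-methylphenyl with a true number are both absent from the compounds shown. From the compounds shown here alone, whether an amine, a carboxylic acid or a longer chain on this phenyl would shift the number beyond the scatter also stays open.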